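Series notes: compounds 1 to 4, whole-organism dosing

A few compounds are considered here, and "the series" means these few. Any claim that something is new, unique, unknown or untested is made for them only; others in the source may bear on it.

Measured so far:
Compound 1, `OC(CSc1ncnc2[nH]cnc12)CN1CCN(C(c2ccc(F)cc2)c2ccc(F)cc2)CC1`: in a functional assay on the whole organism with Canis familiaris (Canis lupus familiaris) as the target (a higher number here means that more compound is needed for the effect, a lower number that less compound is needed), compound 1 gives 0.15 mg/kg.
Compound 2, `CC(=O)OC(CSc1[nH]cnc2ncnc1-2)CN1CCN(C(c2ccc(F)cc2)c2ccc(F)cc2)CC1`: compound 2 gives 0.3 mg/kg.
Compound 3, `Fc1ccc(C(c2ccc(F)cc2)N2CCN(CCCSc3[nH]cnc4ncnc3-4)CC2)cc1`: compound 3 gives 1.3 mg/kg.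

Compound 1 carries the lowest number of the three; compound 2 lies within the scatter of it, while compound 3 sits well beyond. Among the compounds with values here, the single step between directly comparable structures is a 4.3-fold higher number from compound 2 to compound 3 (0.64 log units; beyond the scatter).

Compound 4, `CN(CC(O)CN1CCN(C(c2ccc(F)cc2)c2ccc(F)cc2)CC1)c1[nH]cnc2ncnc1-2`, is not yet measured. It differs from compound 1 as follows: a group of 11 heavy atoms (6 carbon, 5 nitrogen; one five-membered aromatic ring with 2 hetero atoms, one six-membered aromatic ring with 2 hetero atoms) in place of a group of 10 heavy atoms (5 carbon, 4 nitrogen, 1 sulfur; one five-membered aromatic ring with 2 hetero atoms, one six-membered aromatic ring with 2 hetero atoms), on a saturated chain carbon, two bonds along the chain from an oxygen on a saturated carbon. Within the data shown here, no measured pair in the set alters this part of the molecule; the one measured step concerns the chain substituent, which compound 4 keeps as in compound 1. The chain with an oxygen on a saturated carbon in compound 1 and the acetoxy chain in compound 2 give numbers within the scatter of each other, so nothing here argues for a large shift. The expected step is therefore a 1.7-fold higher number from compound 1 to compound 4 (0.22 log units; within the scatter), anticipated to remain within the scatter. Compound 4 is estimated at 0.25 mg/kg, with a range of 0.08 mg/kg to 0.8 mg/kg.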

Compound 4, dose for half-maximal effect: 0.74 mg/kg
The estimate for compound 4 lay 3.0-fold (0.47 log units) below the measured number; the range from low to high includes it.
By their numbers in this assay, from the lowest: compounds 1 and 2 (each within the scatter of the next); then compounds 4 and 3 (each within the scatter of the next).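

Series notes, continued: compound 4 gives the first measured change at this position, on a saturated chain carbon, two bonds along the chain from an oxygen on a saturated carbon. In this assay, the group of 11 heavy atoms (6 carbon, 5 nitrogen) in place of the group of 10 heavy atoms (5 carbon, 4 nitrogen, 1 sulfur) gives a 4.9-fold higher number from compound 1 to compound 4 (0.69 log units; beyond the scatter), so the dose responds to this position as well as to the chain substituent, even though the counts of hydrogen-bond donors and acceptors stay the same. No measurement available here accounts for this step.

A single pair cannot show which part of the exchanged group carries the step. Going by these compounds, how an ether oxygen or an unmethylated amine would compare with the sulfur-containing group of compound 1 remains open.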